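Swapping a Phenyl for Trifluoromethyl on a Cytotoxic Core

The source may report more compounds than this note shows. Statements on the series, on what has been measured and on what is new or still open speak of the compounds shown alone.

In a functional assay on DU-145 cells (Homo sapiens) for cytotoxicity, read by MTT assay, with a stated time of 72 h (on this read-out lower numbers stand for stronger inhibition and higher numbers for weaker inhibition), compound 1 `O=c1ccc2nc(-c3ccccc3)nn(-c3ccccc3)c-2c1` gives 230 nM. Compound 2 `CCNc1cc2nc(-c3ccccc3)nn(-c3ccccc3)c-2cc1=O` gives 220 nM, level with compound 1 within the scatter. Compound 3 `CCOc1cc2nc(-c3ccccc3)nn(-c3ccccc3)c-2cc1=O` reports > 5000 nM, which is a limit of the assay and not a number. Compound 4 `O=c1ccc2nc(C(F)(F)F)nn(-c3ccccc3)c-2c1` changes compound 1 elsewhere: trifluoromethyl in place of phenyl on an aromatic carbon, with trifluoromethyl in place of phenyl. Neither measured step touches that phenyl: ethylamino gave a 1.0-fold lower number from compound 1 to compound 2 (0.02 log units; within the scatter), whereas ethoxy gave an at least 21-fold higher number from compound 1 to compound 3 (1.33 log units; beyond the scatter). These steps show that a single change can do nothing or a great deal, so the guess stays wide, and no shift beyond the scatter is expected in this assay. The expected change is a 1.2-fold lower number from compound 1 to compound 4 (0.06 log units; within the scatter). Compound 4 is estimated at 200 nM, within a range of 40 nM to 1500 nM.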

Compound 4, half-maximal inhibitory concentration: 850 nM
For compound 4 the middle estimate is 4.3-fold (0.63 log units) below the measured one, and the stated range covers the measured number.
By their numbers in this assay, from the lowest: compounds 2 and 1 (each within the scatter of the next); then compound 4. At a limit, above all of these: compound 3.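

Among these compounds, the earlier steps left this phenyl untouched, so compound 4 gives the first reading at the aromatic carbon between two ring nitrogen atoms. In this assay, this position responds to change, though not drastically: trifluoromethyl in place of phenyl gives a 3.7-fold higher number from compound 1 to compound 4 (0.57 log units; beyond the scatter), and the shift lies beyond the scatter. Nothing shown here accounts for this shift. As far as these compounds go, with only one replacement at this position, it remains open how a methyl, an amine or a longer chain would compare. Also open, from the compounds shown here alone, is whether trifluoromethyl and ethylamino together would behave as each does alone.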